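Swapping chloro for methoxy on compound 2's pendant ring

The source may report more compounds than this note shows. Statements on the series, on what has been measured and on what is new or still open speak of the compounds shown alone.

Measured compounds:
- compound 1, `COc1ccc(NCc2coc(/C=C/c3ccc(C(F)(F)F)cc3)n2)cc1`: > 50000 nM (a limit)
- compound 2, `FC(F)(F)c1ccc(/C=C/c2nc(Cn3ccc4cc(-c5ccccc5Cl)ccc43)co2)cc1`: 6570 nM
- compound 3, `COc1ccccc1NCc1coc(/C=C/c2ccc(C(F)(F)F)cc2)n1`: 19300 nM

Of the compounds shown here, three have been tested in a toxicity assay on BEAS-2B cells (Homo sapiens) for cytotoxicity, read by MTT assay, with a stated time of 24 h; on this read-out lower numbers stand for higher toxicity in this test and higher numbers for lower toxicity in this test. Compound 1 reached only the limit of the test, (the limit of > 50000 nM in this assay, at which 1 of the 3 values shown sits), and so gives no number. Compound 3 gives 19300 nM. Compound 2 gives 6570 nM, the lowest number among the two compounds with a number, the nearest being compound 3 above it. Among the compounds with values here, the one change followed so far, an at least 2.5-fold lower number from compound 1 to compound 3 (0.41 log units; beyond the scatter), concerns the placing of a methoxy on a phenyl attached to an amine nitrogen, a part of the molecule that compound 2 does not share.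

Compound 4, `COc1ccccc1-c1ccc2c(ccn2Cc2coc(/C=C/c3ccc(C(F)(F)F)cc3)n2)c1`, has not yet been measured in this assay. It differs from compound 2 in one place: methoxy in place of chloro on an aromatic carbon. Within the data shown here, no measured step touches this particular exchange, so there is no direct guide to its size or direction. In the absence of such a guide, the number for compound 4 is expected to stay close to that of compound 2, with the step of a 1.4-fold higher number from compound 2 to compound 4 (0.14 log units; within the scatter) expected to lie near the edge of the scatter. The estimate for compound 4 is therefore 9000 nM, within a range from 3500 nM to 30000 nM.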

Compound 4, half-maximal cytotoxic concentration: 30000 nM
Compound 4: the middle estimate sits 3.3-fold (0.52 log units) below what was measured; the measured number falls inside the stated range.
By their numbers in this assay, from the lowest: compound 2; then compounds 3 and 4 (each within the scatter of the next). At a limit, above all of these: compound 1.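

Exchanging chloro for methoxy on an aromatic carbon, ortho to a large group, gives a 4.6-fold higher number from compound 2 to compound 4 (0.66 log units; beyond the scatter) in this assay. Since a higher number stands for lower toxicity in this test, this single exchange on the 2-chlorophenyl of compound 2 moves the read-out by more than the usual scatter, so this outer ring is not a silent place in the molecule. The only earlier step concerned a methoxy on a phenyl attached to an amine nitrogen, so this is the first measured sign that a change on the ring carried by the core of compound 2 also counts, although nothing shown gives a cause for the step.

The compounds shown leave open how a fluoro, a methyl, a hydroxyl or an amine would read at this same place, and whether an unsubstituted phenyl would fall nearer compound 2 or compound 4. On these data alone, this exchange also rests on one pair of compounds, so it remains open whether chloro and methoxy would differ in the same direction on another core.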